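A few compounds are considered here, and "the series" means these few. Any claim that something is new, unique, unknown or untested is made for them only; others in the source may bear on it.

Measured so far, all in the same assay:

Compound 1, `Fc1ccc(Sc2[nH]cnc3nccc2-3)cc1`, gives 3%
Compound 2, `Clc1ncnc2ncn(Cc3ccccc3)c12`, gives 0%
Compound 3, `Fc1ccc(Cn2cnc3ncnc(Cl)c32)cc1`, gives 8%

These three numbers come from an assay on isolated protein for inhibition of Ca2+/calmodulin-dependent protein kinase II (CaM kinase II) (Rattus norvegicus), tested at 30 uM (on this read-out lower numbers stand for less inhibition and higher numbers for more inhibition at the one concentration tested (going by the name of the read-out)), and all three sit low. Compound 3 holds the highest of the three numbers, yet its distance to compound 1 and to compound 2 lies within the usual scatter of this assay, so no order among the three can be claimed. Among the compounds with values here, the only step between two measured compounds that differ in one place runs from compound 2 to compound 3: a number 8 percentage points higher from compound 2 to compound 3 (within the scatter), for fluoro in place of hydrogen on an aromatic carbon.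

Compound 4, `COc1ncnc2ncn(Cc3ccc(F)cc3)c12`, is the next compound for this assay. It differs from compound 3 in one place: methoxy in place of chloro on an aromatic carbon. Within the data shown here, no measured pair shows a methoxy in place of a chloro, so no step bears directly on this change; the one step that exists concerns a different group at a different position and stayed within the scatter. With compound 3 at 8% and both other compounds close by, the expectation for compound 4 is a step of about a number 3 percentage points lower from compound 3 to compound 4 (within the scatter), that is, nothing beyond the scatter. Compound 4 is therefore estimated at 5%, in the range 0% to 15%.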

Compound 4, a percentage reported as inhibition, at one concentration (the size of the read-out at that concentration, not a potency): 2%
Estimate against measurement, compound 4: 3 percentage points above, within the range that was stated.
By their numbers in this assay, from the lowest: compounds 2, 4, 1 and 3 (each within the scatter of the next).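

Within the data shown here, exchanging chloro for methoxy on this aromatic carbon, next to the ring nitrogen, gives the first reading of any change at this position in this assay: a number 6 percentage points lower from compound 3 to compound 4 (within the scatter). The earlier compounds shown here offered only a change on the other aromatic ring, so this step adds that a swap at this second place, where the entering methoxy carries a hydrogen-bond acceptor and the leaving chloro does not, also stays inside the scatter, and the two groups cannot be ranked against each other here. No measurement among those shown offers any explanation for this result.

From the compounds shown here alone, what an amine, a carboxylic acid or a longer alkoxy chain would give on this same carbon remains open, as does whether any group here can move the number of the shared core beyond the scatter at the one concentration tested. Among these compounds, also open is whether methoxy would read the same without the fluoro on the benzyl group, since the only fluoro step shown sits on the chloro compounds.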